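The compounds below may be only part of what the source reports. "The series", "measured", "known", "first", "only" and "open" are said of these compounds alone.

Measured in a functional assay on MCF7 cells (Homo sapiens) for antiproliferative activity, read by MTT assay, with a stated time of 24 h; a higher number here means a weaker inhibitor, a lower number a stronger inhibitor:
Compound 1 `O=S(=O)(Nc1ccc2cc[nH]c2c1)c1ccc(F)cc1` gives 30900 nM
Compound 2 `O=C(Nc1ccc2cc[nH]c2c1)c1cccc(C(F)(F)F)c1` gives 30600 nM
Compound 3 `O=C(Nc1ccc2cc[nH]c2c1)c1ccc(F)cc1` gives 45900 nM

The three measured compounds sit close together. Compound 1 lies within the usual scatter of both compound 2 and compound 3, so the data do not separate it from either of them.

Compound 4 `O=S(=O)(Nc1ccc2cc[nH]c2c1)c1ccc(Cl)cc1` has not yet been measured. It keeps the core of compound 1 and carries chloro in place of fluoro on an aromatic carbon, para to a large group (chloro in place of fluoro on an aromatic carbon). Among the compounds with values here, no measured pair shows this exchange, so the data offer no direct precedent for it. In this assay a step no larger than the scatter is expected, with no firm direction. That expectation rests on the value of compound 1 (30900 nM) and on the narrow spread of the three measured values. The step expected is small (a 1.1-fold lower number from compound 1 to compound 4 (0.06 log units; within the scatter)). The estimate for compound 4 is 27000 nM with an expected range from 13000 nM to 55000 nM in this assay.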

Compound 4, half-maximal inhibitory concentration: 54000 nM
The estimate for compound 4 lay 2.0-fold (0.30 log units) below the measured number, within the range that was stated.
By their numbers in this assay, from the lowest: compounds 2, 1, 3 and 4 (each within the scatter of the next).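

The exchange of fluoro for chloro on an aromatic carbon, para to a large group, now has a direct reading in this assay: it gives a 1.7-fold higher number from compound 1 to compound 4 (0.24 log units; within the scatter). Within the data shown here, this is the first measured pair at this position, and it shows that a single-atom halogen exchange there, on the core of compound 1, does not move the number beyond the scatter. No information on the cause of this small step is available, and nothing here explains the result.

With only fluoro and chloro seen at this place, the compounds shown leave open whether the position responds at all to a more different group, such as an amine, a carboxylic acid or a longer chain. They also leave open whether any such group would give a step beyond the scatter.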